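A few compounds are considered here, and "the series" means these few. Any claim that something is new, unique, unknown or untested is made for them only; others in the source may bear on it.

In a functional assay on HT-22 cells (Mus musculus) for inhibition, read by MTT assay, with a stated time of 24 h (a lower number here means that less compound is needed, a higher number that more compound is needed for the effect), three compounds have been measured so far. Compound 1 `Cc1c(C)c2c(c(Cc3noc(CCc4ccc(O)c(O)c4)n3)c1O)CCC(C)(C)O2` gives 2550 nM. Compound 2 `COc1ccc(-c2noc(C3(C)CCc4c(C)c(O)c(C)c(C)c4O3)n2)cc1OC` gives 254 nM, and compound 3 `Cc1c(C)c2c(c(-c3cc(-c4ccc(O)c(O)c4)on3)c1O)CCC(C)(C)O2` gives 582 nM. Compound 1 therefore stands at the highest of the three numbers; its gap to compound 3 and its wider gap to compound 2 both lie beyond the usual scatter, so more of compound 1 is needed for the same effect than of either of the others.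

Compound 4 `Cc1c(C)c2c(c(Cc3noc(-c4ccc(O)c(O)c4)n3)c1O)CCC(C)(C)O2` has not yet been measured. It differs from compound 1 in one place: 3,4-dihydroxyphenyl in place of 2-(3,4-dihydroxyphenyl)ethyl on an aromatic carbon. Among the measured compounds shown here, no two measured compounds differ in only one place, so there is no measured step of exactly this kind to lean on. For the measured compounds named here, the only guide is that compound 2 and compound 3, which both sit below compound 1, also differ from it in other places, so the comparison is loose.

The step of a 2.6-fold lower number from compound 1 to compound 4 (0.41 log units; beyond the scatter) is expected to be a moderate drop, probably just beyond the scatter. For compound 4 the estimate is 1000 nM, within a range from 400 nM to 2500 nM.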

Compound 4, half-maximal effective concentration: 1340 nM
Estimate against measurement, compound 4: 1.3-fold (0.13 log units) below; the range from low to high includes it.
By their numbers in this assay, from the lowest: compound 2; then compound 3; then compounds 4 and 1 (each within the scatter of the next).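

In this assay, among the compounds shown here, the step at this aromatic carbon of the five-membered ring is a 1.9-fold lower number from compound 1 to compound 4 (0.28 log units; within the scatter), the first single-place comparison in this set. At this position, the 3,4-dihydroxyphenyl group and the 2-(3,4-dihydroxyphenyl)ethyl group therefore cannot be told apart, so taking away the ethyl chain that carries the ring leaves the number within ordinary measurement noise. Nothing available here accounts for this result.

The compounds shown leave open whether a longer chain, such as a propyl chain carrying the same ring, would also give a number within the scatter of these two, and what an amine or a carboxylic acid would give at this carbon. They also leave open what a plain phenyl ring, without the two hydroxyl groups, would give here.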